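Swapping the para substituent: trifluoromethyl to nitro

The source may report more compounds than this note shows. Statements on the series, on what has been measured and on what is new or still open speak of the compounds shown alone.

Three compounds share one core and differ only in the group on the far benzene ring. Compound 1 `CC(=O)c1cccc(OCc2ccc(F)cc2)c1` carries fluoro and in an assay on isolated protein for inhibition of Amine oxidase [flavin-containing] B (Homo sapiens), read by Amplex Red, with a stated time of 15 min (a higher number here means a weaker inhibitor, a lower number a stronger inhibitor), compound 1 gives 86.4 nM. Compound 2 `CC(=O)c1cccc(OCc2ccc(C)cc2)c1` carries methyl, and in this assay compound 2 gives 140 nM. Compound 3 `CC(=O)c1cccc(OCc2ccc(C(F)(F)F)cc2)c1` carries trifluoromethyl, and in this assay compound 3 gives 43.2 nM, the lowest of the three numbers; one gap is a 2.0-fold lower number from compound 1 to compound 3 (0.30 log units; within the scatter), the other gap is a 3.2-fold lower number from compound 2 to compound 3 (0.51 log units; beyond the scatter).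

Compound 4 `CC(=O)c1cccc(OCc2ccc([N+](=O)[O-])cc2)c1` differs from compound 3 by nitro in place of trifluoromethyl on an aromatic carbon. Within the data shown here, no measured step involves nitro, so only the two steps into compound 3 bear on it: one within the scatter and one modest. Since every change made so far at this position has moved this assay by no more than a modest amount, the step from compound 3 to compound 4 is expected to stay within the scatter, a 1.4-fold higher number from compound 3 to compound 4 (0.14 log units; within the scatter). Compound 4 is therefore estimated at 60 nM, with a range from 20 nM to 180 nM.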

Compound 4, half-maximal inhibitory concentration: 75.4 nM
For compound 4 the middle estimate is 1.3-fold (0.10 log units) below the measured one; low and high end bracket the measured number.
By their numbers in this assay, from the lowest: compounds 3, 4, 1 and 2 (each within the scatter of the next, the first and the last beyond it).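

Nitro brings 2 hydrogen-bond acceptors where trifluoromethyl has none, yet in this assay the change stays within the scatter (a 1.7-fold higher number from compound 3 to compound 4 (0.24 log units; within the scatter)). The other two steps also stay within it (a 1.9-fold lower number from compound 2 to compound 4 (0.27 log units; within the scatter); a 1.1-fold lower number from compound 1 to compound 4 (0.06 log units; within the scatter)), so compound 4 sits within the scatter of all three earlier compounds, even though compound 2 and compound 3 lie beyond the scatter of each other. So this position accepts a group with hydrogen-bond acceptors without a step beyond the scatter, though nothing available explains this result.

Going by these compounds, whether an amine or a carboxylic acid at this place would fit as well remains open, as does the effect of a longer chain. All four compounds also share one core, so they cannot show how a change to its carbonyl would read.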